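Cytotoxicity notes on a halobenzyl triazole pair

This account rests on a few compounds, and the source may have more. Where it says the series, first, only, none or still open, it means among the compounds named here.

Compound 1 `O=C1/C(=C/c2ccccc2F)CN(Cc2cn(Cc3ccccc3F)nn2)C/C1=C\c1ccccc1F` and compound 2 `O=C1/C(=C/c2ccccc2F)CN(Cc2cn(Cc3ccccc3Cl)nn2)C/C1=C\c1ccccc1F` share one core; compound 3 `Cc1ccc(/C=C2\CN(Cc3cn(Cc4ccccc4F)nn3)C/C(=C\c3ccc(C)cc3)C2=O)cc1` is built on a different core, and the difference between the two cores is not broken down here. In an ADME assay on HEK293 cells (Homo sapiens) for cytotoxicity, read by MTT assay, with a stated time of 24 h (on this read-out lower numbers stand for stronger inhibition and higher numbers for weaker inhibition), compound 1 gives 41200 nM, and compound 2 gives 33200 nM. The change between them is chloro in place of fluoro on an aromatic carbon, and the step it made is a 1.2-fold lower number from compound 1 to compound 2 (0.09 log units; within the scatter). For compound 3 the read-out in this assay is a limit rather than a number, > 100000 nM, which is the limit of > 100000 nM in this assay, at which 1 of the 3 values shown sits. Compound 4 `Cc1ccc(/C=C2\CN(Cc3cn(Cc4ccccc4Cl)nn3)C/C(=C\c3ccc(C)cc3)C2=O)cc1` has not been measured; it differs from compound 3 by chloro in place of fluoro on an aromatic carbon, the same change as that from compound 1 to compound 2, with the place described in the same words. Because the step of a 1.2-fold lower number from compound 1 to compound 2 (0.09 log units; within the scatter) stayed within the scatter, the step that the limit leaves unreadable from compound 3 to compound 4 is expected to be small as well. Compound 4 is therefore estimated at 150000 nM, with a range from 60000 nM to 400000 nM, and is expected most likely to reach only the limit again.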

Compound 4, half-maximal inhibitory concentration: 91500 nM
The estimate for compound 4 lay 1.6-fold (0.21 log units) above the measured number; low and high end bracket the measured number.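

In this assay, the change from 2-fluorobenzyl to 2-chlorobenzyl on the core of compound 3 gives an at least 1.0-fold lower number from compound 3 to compound 4 (0.03 log units; that floor lies within the scatter). Compound 3 carries a limit of the assay and not a number: the limit of > 100000 nM in this assay, at which 1 of the 4 values shown sits. Set side by side, the two steps fit a change that carries over from one core to the other with little effect, but a larger step on the core of compound 3 is not excluded, and the carry-over itself is therefore not shown: the same change on two cores in this assay, a 1.2-fold lower number (0.09 log units; within the scatter) from compound 1 to compound 2 and an at least 1.0-fold lower number (0.03 log units; that floor lies within the scatter) from compound 3 to compound 4; the limit leaves it open whether they differ.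

The compounds shown leave open how this read-out responds when the halogen on the benzyl group gives way to another kind of group, such as a methoxy group, a nitrile or an amine. They also leave the difference between the two cores unresolved, and no single part of it can be read from these compounds.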